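This account rests on a few compounds, and the source may have more. Where it says the series, first, only, none or still open, it means among the compounds named here.

Compounds measured in a functional assay on HOP-62 cells (Homo sapiens) for inhibition, read by sulforhodamine B assay, with a stated time of 48 h; on this read-out higher numbers stand for weaker inhibition of growth and lower numbers for stronger inhibition of growth:
- compound 1 `COc1cc(-c2cc(/C=C/C(=O)c3ccc(N)cc3)[nH]n2)cc(OC)c1OC`: 1770 nM
- compound 2 `COc1ccc(-c2cc(/C=C/C(=O)c3cc(OC)c(OC)c(OC)c3)[nH]n2)cc1OC`: 1450 nM

Compound 1 has the highest of the two numbers, yet compound 2 lies within the scatter of it, so the two cannot be told apart. From the compounds shown here alone, compound 3 `COc1ccc(C(=O)/C=C/c2cc(-c3cc(OC)c(OC)c(OC)c3)n[nH]2)cc1OC` is untested. It differs from compound 1 in one place: 3,4-dimethoxyphenyl in place of 4-aminophenyl on a carbonyl carbon. Within the data shown here, no step between measured compounds separates this exchange, so its effect is unknown; the two values seen here suggest no step beyond the scatter. Compound 3 is therefore expected to give 1500 nM, with a range from 500 nM to 4500 nM, and the expected step of a 1.2-fold lower number from compound 1 to compound 3 (0.07 log units; within the scatter) is small.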

Compound 3, concentration for 50% growth inhibition: 1440 nM
Compound 3: the middle estimate sits 1.0-fold (0.02 log units) above what was measured, within the range that was stated.
By their numbers in this assay, from the lowest: compounds 3, 2 and 1 (each within the scatter of the next).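

In this assay, among these compounds, 3,4-dimethoxyphenyl in place of 4-aminophenyl on a carbonyl carbon gives a 1.2-fold lower number from compound 1 to compound 3 (0.09 log units; within the scatter) and is the first exchange read at this position. It shows that 4-aminophenyl can give way there to a group with no hydrogen-bond donor while the step stays within the scatter. No measurement at hand speaks to why this is so. Open, from the compounds shown here alone, is whether a phenyl ring carrying a carboxylic acid would also stay within the scatter on this carbonyl carbon. Also open, going by these compounds, is whether an open alkyl chain could stand there in place of the ring.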